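A few compounds are considered here, and "the series" means these few. Any claim that something is new, unique, unknown or untested is made for them only; others in the source may bear on it.

In a physicochemical assay for solubility (a lower number here means a less soluble compound, a higher number a more soluble compound), compound 1 (`C[C@H](N)C(=O)N[C@@H]1CN(c2nc3c(cc2F)c(=O)c(C(=O)O)cn3C2CC2)[C@H]1C`) gives > 500 ug/mL as a limit of the assay. Compound 2 (`C[C@H](N)C(=O)N[C@@H]1CN(c2cc3c(cc2F)c(=O)c(C(=O)O)cn3-c2ccc(F)cc2F)[C@H]1C`) gives > 500 ug/mL and this too is a limit, not a number. Going by the values given here, compound 3 (`C[C@@H](N)C(=O)N[C@@H]1CN(c2nc3c(cc2F)c(=O)c(C(=O)O)cn3C2CC2)[C@H]1C`) gives 495 ug/mL as the only true number.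

Compound 4 (`CCC[C@H](N)C(=O)N[C@@H]1CN(c2cc3c(cc2F)c(=O)c(C(=O)O)cn3-c2ccc(F)cc2F)[C@H]1C`) differs from compound 2 by ethyl in place of hydrogen on a saturated chain carbon, two bonds along the chain from an amine nitrogen and a carbonyl carbon with ethyl in place of hydrogen on a saturated chain carbon, two bonds along the chain from an amine nitrogen and a carbonyl carbon, so that 1-aminoethyl becomes 1-aminobutyl.

Among the compounds with values here, the one measured step is a number no higher from compound 1 to compound 3 (the limit leaves the size open) and its size cannot be read. It bears only weakly here, given the fact that compounds 1 and 3 differ only in the configuration as drawn as its whole structural content. Within the data shown here, no measured step carries the new change.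

The estimate is therefore anchored on compound 3 at 495 ug/mL in the absence of a number for compound 2. A modest fall is expected, read as an at least 1.4-fold lower number from compound 2 to compound 4 (0.15 log units; that floor lies within the scatter) in this assay and still uncertain. For compound 4 the estimated value is 350 ug/mL with an expected range of 120 ug/mL to 700 ug/mL in this read-out.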

Compound 4, solubility: > 500 ug/mL
Compound 4: a limit, no number (the forecaster's own chance of this, stated with the estimate: 35%); middle value at least 1.4-fold (0.15 log units) away from the limit.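

In this assay compound 2 gives > 500 ug/mL, a limit of the assay. Compound 4 gives > 500 ug/mL, also a limit, so no step can be read from compound 2 to compound 4. On these data alone, the size and direction of any shift from 1-aminoethyl to 1-aminobutyl in this assay remain open.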